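A few compounds are considered here, and "the series" means these few. Any claim that something is new, unique, unknown or untested is made for them only; others in the source may bear on it.

Three compounds of this series have been described, and they share the same core. Compound 1 `COc1ccc(S(=O)(=O)Nc2ccc(C(=O)CSC(C)=O)cn2)cc1` carries a methoxy group on its outer aromatic ring, compound 2 `CC(=O)SCC(=O)c1ccc(NS(=O)(=O)c2ccc(OCCCN3CCCCC3)cc2)nc1` carries a longer chain ending in a ring, and compound 3 `CC(=O)SCC(=O)c1ccc(NS(=O)(=O)c2ccc(OCCCO)cc2)nc1` carries a 3-hydroxypropoxy group at the same position. In a functional assay on U226 cells (Homo sapiens) for cytotoxicity (a higher number here means that more compound is needed for the effect, a lower number that less compound is needed), compound 2 gives 800 nM. In this assay compound 1 is recorded as "not determined" (no result reported). In this assay compound 3 is recorded as "not determined" (no result reported), so compound 3 stands without any number of its own, and a second compound of the set is in the same position.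

The step considered here leads from compound 3 to compound 4 `CC(=O)SCC(=O)c1ccc(NS(=O)(=O)c2ccc(OC3CCCN(C)C3)cc2)nc1`. The change is 1-methylpiperidin-3-yl in place of 3-hydroxypropyl on an oxygen on an aromatic ring. The 3-hydroxypropyl group, with its one hydrogen-bond donor, leaves, and the 1-methylpiperidin-3-yl group, with no hydrogen-bond donor and one hydrogen-bond acceptor, enters on the oxygen attached to the aromatic ring.

Going by the values given here, because compound 3 has no value in this assay, no step from it can be sized, and the direction of the change cannot be read from the data. Among the compounds with values here, the only anchor is compound 2. Because compound 2 gives 800 nM, compound 4 is expected to lie near 800 nM, within a range from 250 nM to 2500 nM.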

Compound 4, half-maximal effective concentration: 1200 nM
Compound 4: middle estimate off by 1.5-fold (0.18 log units), on the low side; the measured number falls inside the stated range.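

In this assay the step shows a 1.5-fold higher number from compound 2 to compound 4 (0.18 log units; within the scatter), so this position now has a second number, and the two groups on the oxygen on the aromatic ring cannot be told apart by it. The 3-(piperidin-1-yl)propyl group of compound 2 and the 1-methylpiperidin-3-yl group of compound 4 both hold a piperidine ring, yet the propyl chain of compound 2 is absent from compound 4, and this difference in how the ring is carried leaves no mark beyond the scatter in this pair. Nothing at hand gives a reason for this result.

The change from 3-hydroxypropyl itself cannot be read, since compound 3 has no number and no step from it can be sized, and the same holds for the methoxy group of compound 1, so the compounds shown do not tell whether a ring-bearing group matters here at all. Also open, going by these compounds, is what a carboxylic acid, a morpholine ring or an open-chain dimethylamino group on the same oxygen would give.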